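The compounds below may be only part of what the source reports. "The series", "measured", "known", "first", "only" and "open" are said of these compounds alone.

In a functional assay for inhibition, with Rattus norvegicus as the target (on this read-out higher numbers stand for weaker inhibition and lower numbers for stronger inhibition), compound 1 `Nc1c(Nc2cccnc2)c(=O)c1=O` gives > 30000 nM, which is a limit of the assay and not a number. For the measured compounds named here, compound 2 `CC(C)C(C)/N=c1\c(O)c(O)\c1=N/c1ccc(C#N)cc1` gives 1900 nM in this assay, and this is the only actual number available so far. It therefore serves as the single anchor for what follows, with no series of measured values around it to show how much this kind of compound can vary.

Compound 3 `CCCCCCC/N=c1\c(O)c(O)\c1=N/c1ccc(C#N)cc1` differs from compound 2 in one place: heptyl in place of 1,2-dimethylpropyl on a double-bonded nitrogen. In words, it carries heptyl in place of 1,2-dimethylpropyl on a double-bonded nitrogen.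

Going by the values given here, no measured pair of compounds shows what a change at this place does, so any forecast is uncertain. A modest weakening in this assay is expected, meaning a somewhat higher number, though a result within the usual scatter of compound 2 at 1900 nM would be no surprise. The expected change is a 1.6-fold higher number from compound 2 to compound 3 (0.20 log units; within the scatter). For compound 3 the estimated value is 3000 nM, with an expected range of 700 nM to 13000 nM.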

Compound 3, half-maximal inhibitory concentration: > 30000 nM
Compound 3 gave a limit, no number; the forecaster's own chance of this, stated with the estimate: 8%; at least 10-fold (1.00 log units) between middle value and limit.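

The group on the double-bonded nitrogen matters a great deal in this assay: heptyl in place of 1,2-dimethylpropyl gives an at least 15-fold higher number from compound 2 to compound 3 (1.19 log units; beyond the scatter). The earlier compounds shown here offered no measured step at this place, and this one shows that exchanging one carbon-only group for another, with no ring, hydrogen-bond donor, hydrogen-bond acceptor or net charge entering or leaving, is enough to move the result beyond the scatter. The step gives only a minimum size, not an exact one, because the result for compound 3 is a limit of the assay and not a number: the limit of > 30000 nM in this assay, at which 2 of the 3 values shown sit.

The compounds shown leave open which difference counts, as heptyl and 1,2-dimethylpropyl differ both in their number of carbons and in their branching. As far as these compounds go, it also remains open whether a shorter chain such as butyl, or a chain ending in an amine or a carboxylic acid, would stay close to compound 2 at 1900 nM. Equally open, from the compounds shown here alone, is whether such a chain would also reach the limit of the assay.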